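The source may report more compounds than this note shows. Statements on the series, on what has been measured and on what is new or still open speak of the compounds shown alone.

Compound 1, `COc1cc(-c2cc(-c3ccc(N)cc3)nc(-c3ccccc3)n2)cc(OC)c1OC`: in a functional assay on HT-29 cells (Homo sapiens) for inhibition, read by MTT assay, with a stated time of 48 h (on this read-out lower numbers stand for stronger inhibition and higher numbers for weaker inhibition), compound 1 reaches only a limit of the assay, > 25000 nM.
Compound 2, `COc1cc(-c2cc(-c3ccccc3)nc(-c3ccccc3)n2)cc(OC)c1OC`: compound 2 gives 7930 nM.
Compound 3, `COc1cc(-c2cc(-c3ccc(O)cc3O)nc(-c3ccccc3)n2)cc(OC)c1OC`: compound 3 gives 4960 nM.

All three share one core and differ only in a single aromatic ring attached to it. Among the two numbers actually read out, compound 2 stands highest; its nearest neighbour is compound 3, a step of a 1.6-fold lower number from compound 2 to compound 3 (0.20 log units; within the scatter), which does not count as a real difference. The step from compound 1 is an at least 3.1-fold lower number from compound 1 to compound 2 (0.49 log units; beyond the scatter), although compound 1 sits only at the limit of > 25000 nM in this assay, at which 1 of the 3 values shown sits.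

Compound 4, `COc1ccc(-c2cc(-c3cc(OC)c(OC)c(OC)c3)nc(-c3ccccc3)n2)cc1`, has not yet been measured. It differs from compound 2 by methoxy in place of hydrogen on an aromatic carbon; cut one bond further out, this reads phenyl to 4-methoxyphenyl. Going by the values given here, two measured steps touch that same position of the molecule: a 1.6-fold lower number from compound 2 to compound 3 (0.20 log units; within the scatter) stayed within the scatter, while an at least 3.1-fold lower number from compound 1 to compound 2 (0.49 log units; beyond the scatter) went beyond it. Neither involves a methoxy group, so the expectation is cautious: a step within the scatter, with a slight lean towards a higher number. Compound 4 is therefore expected to give 9000 nM, between 3500 nM and 25000 nM. That estimate amounts to a step of a 1.1-fold higher number from compound 2 to compound 4 (0.05 log units; within the scatter).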

Compound 4, half-maximal inhibitory concentration: 4230 nM
Compound 4: the middle estimate sits 2.1-fold (0.33 log units) above what was measured; measured number inside the range.
By their numbers in this assay, from the lowest: compounds 4, 3 and 2 (each within the scatter of the next). At a limit, above all of these: compound 1.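

In this assay, turning phenyl into 4-methoxyphenyl gives no change that can be told apart from scatter: a 1.9-fold lower number from compound 2 to compound 4 (0.27 log units; within the scatter). The 4-methoxyphenyl of compound 4 and the 2,4-dihydroxyphenyl of compound 3 also cannot be told apart, with a 1.2-fold lower number from compound 3 to compound 4 (0.07 log units; within the scatter), so three different rings at this position now show no step beyond the scatter between them. Only the 4-aminophenyl of compound 1 stands apart, with an at least 5.9-fold lower number from compound 1 to compound 4 (0.77 log units; beyond the scatter), which shows that methoxy and amino on the same ring carbon do not read alike, though the value of compound 1 is a limit and gives this step no exact size: the limit of > 25000 nM in this assay, at which 1 of the 4 values shown sits.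

The compounds shown leave open whether another group on this ring carbon, such as a dimethylamino group, a carboxylic acid or a longer chain like butoxy, would bring a step beyond the scatter. They also leave open how far compound 1 truly lies from the others, and whether methoxy elsewhere on this ring would read the same.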